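The compounds below may be only part of what the source reports. "The series", "measured", "known", "first", "only" and "open" are said of these compounds alone.

Measured so far in an assay on MDA-MB-231 cells for binding affinity to C-X-C chemokine receptor type 4 (Homo sapiens), read by immunofluorescence and microscopy, with stated times of 10 min and 30 min; a lower number here means that less compound is needed, a higher number that more compound is needed for the effect:
compound 1, `Cc1ccc(S(=O)(=O)NCc2ccc(CNC(=O)c3ccccc3)cc2)cc1`, gives > 1000 nM;
compound 2, `O=C(NCc1ccc(CNS(=O)(=O)c2ccccc2)cc1)c1ccc(F)cc1`, gives 100 nM;
compound 3, `COc1cccc(C(=O)NCc2ccc(CNS(=O)(=O)c3ccc(C)cc3)cc2)c1`, gives 10 nM.

The value for compound 1 is a limit of this assay and not a number. Among the two numbers shown, compound 3 stands at the lowest, and compound 2 gives a higher one. Within the data shown here, the one step that can be read between compounds differing in a single place is an at least 100-fold lower number from compound 1 to compound 3 (2.00 log units; beyond the scatter), where compound 1 sits at the limit of > 1000 nM in this assay, at which 1 of the 3 values shown sits.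

Compound 4, `Cc1ccc(S(=O)(=O)NCc2ccc(CNC(=O)c3ccc(Cl)cc3)cc2)cc1`, differs from compound 3 in one place: 4-chlorophenyl in place of 3-methoxyphenyl on a carbonyl carbon. This change undoes the methoxy whose arrival in the step from compound 1 to compound 3 was accompanied by that large drop, while bringing in a chlorine instead of leaving hydrogen. Compound 2, carrying a fluorine on its corresponding ring, gives a number between those of compound 1 and compound 3. A step upward is therefore expected, a 15-fold higher number from compound 3 to compound 4 (1.18 log units; beyond the scatter), beyond the scatter. Compound 4 is estimated at 150 nM, within a range from 30 nM to 1000 nM.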

Compound 4, effective concentration (reported as EC, without a stated level of effect): 10 nM
Compound 4: middle estimate off by 15-fold (1.18 log units), on the high side; measured number below the stated range.
By their numbers in this assay, from the lowest: compounds 3 and 4 (each within the scatter of the next); then compound 2. At a limit, above all of these: compound 1.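

In this assay, 4-chlorophenyl in place of 3-methoxyphenyl on a carbonyl carbon gives no change at the digits printed from compound 3 to compound 4 (within the scatter) on this ring, so the low number of compound 3 does not depend on the methoxy alone. Chloro in place of hydrogen on an aromatic carbon gives an at least 100-fold lower number from compound 1 to compound 4 (2.00 log units; beyond the scatter) and stands as a second large step on this ring alongside an at least 100-fold lower number from compound 1 to compound 3 (2.00 log units; beyond the scatter) in the same assay. Both steps start from compound 1, whose value is a limit and not a number: the limit of > 1000 nM in this assay, at which 1 of the 4 values shown sits.

The compounds shown leave open whether the chlorine and the methoxy could trade places on this ring without the number moving. They also leave open how an amine or a carboxylic acid on the same ring would read in this assay.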